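The source may report more compounds than this note shows. Statements on the series, on what has been measured and on what is new or still open speak of the compounds shown alone.

Measured compounds:
- compound 1, `N#Cc1ccccc1-n1cc(COc2cccc(NC(=O)Nc3ccc(Cl)c(C(F)(F)F)c3)c2)nn1`: 1970 nM
- compound 2, `O=C(Nc1cccc(OCc2cn(-c3ccc(Br)cc3)nn2)c1)Nc1ccc(Cl)c(C(F)(F)F)c1`: 2730 nM

Among the measured compounds shown here, in a functional assay on HepG2 cells (Homo sapiens) for inhibition, read by MTT assay, with a stated time of 72 h (on this read-out lower numbers stand for stronger inhibition and higher numbers for weaker inhibition), compound 2 gives 2730 nM, the highest of the two numbers so far; its nearest neighbour is compound 1 with 1970 nM, and the step of a 1.4-fold higher number from compound 1 to compound 2 (0.14 log units; within the scatter) lies within the scatter.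

Compound 3, `O=C(Nc1cccc(OCc2cn(-c3cccc(C(F)(F)F)c3)nn2)c1)Nc1ccc(Cl)c(C(F)(F)F)c1`, is not yet measured. It differs from compound 2 by 3-(trifluoromethyl)phenyl in place of 4-bromophenyl on an aromatic nitrogen.

For the measured compounds named here, the only measured step that bears on this change is a 1.4-fold higher number from compound 1 to compound 2 (0.14 log units; within the scatter), an exchange of the aryl group on the same aromatic nitrogen, which produced no movement beyond the scatter. The present swap is of the same kind, so no step beyond the scatter is expected for compound 3: the expected step is a 1.1-fold lower number from compound 2 to compound 3 (0.04 log units; within the scatter). Compound 3 is accordingly estimated at 2500 nM, with a range from 1000 nM to 6000 nM.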

Compound 3, half-maximal inhibitory concentration: 1270 nM
The estimate for compound 3 lay 2.0-fold (0.29 log units) above the measured number; the measured number falls inside the stated range.
By their numbers in this assay, from the lowest: compounds 3, 1 and 2 (each within the scatter of the next, the first and the last beyond it).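

In this assay the aryl group on the aromatic nitrogen gives its first step beyond the scatter, with 3-(trifluoromethyl)phenyl replacing 4-bromophenyl as a 2.1-fold lower number from compound 2 to compound 3 (0.33 log units; beyond the scatter) and the size of this step remaining modest. With 2-cyanophenyl as the group replaced, the same entering group gives a 1.6-fold lower number from compound 1 to compound 3 (0.19 log units; within the scatter) and stays within the scatter, so this position separates only compound 2 and compound 3, while compound 1 and compound 3 cannot be told apart. No measurement accompanies these numbers that could account for the step.

The compounds shown leave open how an amine or a carboxylic acid on this phenyl group, or a longer alkyl chain in its place, would read in this assay. They also leave open whether the step belongs to the trifluoromethyl group itself or to where it sits, as both differences arrive together in one exchange.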